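Phenyl gives way to naphthalen-2-yl in compound 3

The compounds below may be only part of what the source reports. "The series", "measured", "known", "first", "only" and "open" are said of these compounds alone.

In an ADME assay on NIH3T3 cells (Homo sapiens) for cytotoxicity, read by sulforhodamine B assay, with a stated time of 48 h (on this read-out higher numbers stand for weaker inhibition and lower numbers for stronger inhibition), compound 1 (`CC(=O)OC[C@H]1O[C@@H](n2cc(Cn3cc(C(C)=O)c4ccccc43)nn2)[C@H](OC(C)=O)[C@@H](OC(C)=O)[C@@H]1OC(C)=O`) gives > 200000 nM as its result, which is a limit and not a number. Compound 2 (`CC(=O)OC[C@H]1O[C@@H](n2cc(CN3C(=O)/C(=C/c4ccccc4)c4ccccc43)nn2)[C@H](OC(C)=O)[C@@H](OC(C)=O)[C@@H]1OC(C)=O`) gives > 100000 nM as its result, and this too is only a limit, so compound 2 has no exact value to stand on. Compound 3 (`CC(=O)OC[C@H]1O[C@@H](n2cc(CN3C(=O)/C(=C/c4ccc5ccccc5c4)c4ccccc43)nn2)[C@H](OC(C)=O)[C@@H](OC(C)=O)[C@@H]1OC(C)=O`) differs from compound 2 in one place (naphthalen-2-yl in place of phenyl on a double-bonded chain carbon bound to a double-bonded ring carbon): naphthalen-2-yl in place of phenyl on a double-bonded chain carbon bound to a double-bonded ring carbon. Among the compounds with values here, no measured step exists to scale this change. The estimated change a number no higher from compound 2 to compound 3 (the limit leaves the size open) in this assay is expected to stay within the usual scatter, with neither direction favoured. For compound 3 the estimated value of 100000 nM is expected to lie in a range from 40000 nM to 200000 nM and may again be only a limit.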

Compound 3, half-maximal inhibitory concentration: 28400 nM
The estimate for compound 3 lay 3.5-fold (0.55 log units) above the measured number; the measured number lies below the stated range.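

In this assay, naphthalen-2-yl in place of phenyl on a double-bonded chain carbon bound to a double-bonded ring carbon gives an at least 3.5-fold lower number from compound 2 to compound 3 (0.54 log units; beyond the scatter). This is the first sign that this place can move the read-out, and compound 3 is the only one of the three compounds shown with an exact number rather than a limit. Compound 2 has only a limit, so the step gives a minimum and leaves the full size open: the limit of > 100000 nM in this assay, at which 1 of the 3 values shown sits.

The compounds shown leave open whether naphthalen-1-yl would match naphthalen-2-yl at this place, or whether a phenyl carrying an amine or a carboxylic acid would also lower the number. Within the data shown here, with a single exact value, they also offer no second step against which to scale this one.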